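Methoxy to Bromo: Expecting Compound 3

A few compounds are considered here, and "the series" means these few. Any claim that something is new, unique, unknown or untested is made for them only; others in the source may bear on it.

Measured so far, in a functional assay for inhibition, with a stated time of 5 min, tested at 1 mM; a higher number here means more inhibition at the concentration tested (going by the name of the read-out), a lower number less inhibition:
compound 1, `COc1ccc(/C(Cl)=C/C=C(\C#N)C(=O)c2c[nH]c3ccc(Br)cc23)cc1`, gives 62.2%
compound 2, `COc1ccc(/C(Cl)=C/C=C(\C#N)C(=O)c2c[nH]c3ccccc23)cc1`, gives 61.3%

Compound 1 stands with the higher of these two numbers, but the step of a number 0.9 percentage points lower from compound 1 to compound 2 (within the scatter) is within the scatter, so the two compounds cannot be told apart by this assay. Compound 3, `N#C/C(=C\C=C(/Cl)c1ccc(Br)cc1)C(=O)c1c[nH]c2ccc(Br)cc12`, has not yet been measured. It differs from compound 1 in one place: bromo in place of methoxy on an aromatic carbon. Among the measured compounds shown here, the only measured step, from compound 1 to compound 2, concerns a different position and a different group, so no measured step bears directly on this change. With nothing to point in either direction, the expectation for this assay is no step beyond the scatter. The estimate for compound 3 is therefore a step of a number 2.2 percentage points lower from compound 1 to compound 3 (within the scatter), giving an expected value of 60%, with a range from 42% to 78%.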

Compound 3, a percentage reported as inhibition, at one concentration (the size of the read-out at that concentration, not a potency): 83.6%
Estimate against measurement, compound 3: 23.6 percentage points below; measured number outside the range, above it.
By their numbers in this assay, from the lowest: compounds 2 and 1 (each within the scatter of the next); then compound 3.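

In this assay, among the compounds shown here, placing bromo where methoxy stood on the aromatic ring gives a number 21.4 percentage points higher from compound 1 to compound 3 (beyond the scatter), the first step in this set that lies beyond the scatter. For the compounds shown here, the only earlier step, a number 0.9 percentage points lower from compound 1 to compound 2 (within the scatter), concerned a different place on the molecule, so it is this comparison that shows the group at the 4-position of the phenyl ring can change the read-out, with bromo here giving more inhibition than methoxy. Nothing measured here gives a reason for this rise.

The compounds shown compare only two groups at this position, so it remains open how an amine, a carboxylic acid or a longer alkoxy chain would behave there. On these data alone, it is also open whether the same rise would appear in the core of compound 2, which has hydrogen in place of the other bromo.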